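From aminomethyl to dipropylamino on a shared core

The source may hold more compounds than are shown below. What is called first, only, known or untested is meant among the compounds shown, and "the series" means these compounds.

Of the compounds shown here, three sharing one fused core have been measured in a functional assay on the whole organism with Canis familiaris (Canis lupus familiaris) as the target, at a dose of 5 mg/kg by the intravenous route; on this read-out higher numbers stand for a stronger effect at the one dose given and lower numbers for a weaker effect. Compound 1 `CC(C)(C)c1nc2c(OCc3ccccc3)cccn2c1N` gives 2%, compound 2 `Cc1nc2c(OCc3ccccn3)cccn2c1N` gives 24%, and compound 3 `Cc1nc2c(OCc3ccccc3)cccn2c1CN` gives 49%. Compound 3 thus stands highest of the three: its nearest neighbour is compound 2, which lies beyond the scatter below it, and compound 1 lies further below still, also beyond the scatter. No pair among these three differs in a single place, so no single step can be read from them.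

Compound 4 `CCCN(CCC)c1c(C)nc2c(OCc3ccccc3)cccn12` has not yet been measured. It differs from compound 3 in one place: dipropylamino in place of aminomethyl on an aromatic carbon. The change removes the hydrogen-bond donor that the aminomethyl group carried and brings in a far larger group with no donor. Among the measured compounds shown here, on the numbers available, compound 3 is the only compound with a donor on that carbon of a chain rather than directly on the ring, and it is also the highest. The author expects the step from compound 3 to compound 4 in this assay to be downward and beyond the scatter, a number 29 percentage points lower from compound 3 to compound 4 (beyond the scatter). Compound 4 is therefore estimated at 20% in this assay, within a range from 2% to 42%.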

Compound 4, a percentage reported as inhibition, in the whole organism at one dose (the size of the read-out at that dose, not a potency): 0%
Compound 4: middle estimate off by 20 percentage points, on the high side; the measured number lies below the stated range.
By their numbers in this assay, from the lowest: compounds 4 and 1 (each within the scatter of the next); then compound 2; then compound 3.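

In this assay the aromatic carbon next to the ring nitrogen proves sensitive to what it carries: dipropylamino in place of aminomethyl gives a number 49 percentage points lower from compound 3 to compound 4 (beyond the scatter) on an otherwise unchanged core, leaving compound 4 at 0% at the one dose given. The change alters two things together, since the group that leaves has 2 heavy atoms and 1 hydrogen-bond donor, while the group that enters has 7 heavy atoms and 0 hydrogen-bond donors. No measurement accounts for the fall in the read-out.

This one step cannot separate the lost donor from the added size. Going by these compounds, it also remains open how dimethylamino, methylaminomethyl or a longer chain such as aminoethyl on this carbon would read out on the same core.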